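Pyrazolyl-methyl triazolopyridines: ether replacement in compound 1

The source may hold more compounds than are shown below. What is called first, only, known or untested is meant among the compounds shown, and "the series" means these compounds.

Measured so far, in an assay on isolated protein for inhibition of Myeloperoxidase (Homo sapiens), with a stated time of 10 min; on this read-out lower numbers stand for stronger inhibition and higher numbers for weaker inhibition:
compound 1 `Nc1cc(Cc2ccn(Cc3cccc(Oc4ccccc4)c3)n2)c2nn[nH]c2n1` – 44 nM
compound 2 `Nc1cc(C2CCNCCc3cccc(c3)OCc3cccc(c3)Cn3cc2cn3)c2nn[nH]c2n1` – 17 nM
compound 3 `Nc1cc(Cc2ccn(-c3ccc(F)cc3)n2)c2nn[nH]c2n1` – 53 nM

Compound 1 holds the second highest of the three numbers. Its nearest neighbour is compound 3, whose 53 nM lies within the scatter of compound 1, so no order between the two can be read. Compound 2 stands furthest away, with 17 nM lower than compound 1 beyond the scatter.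

Compound 4 `Nc1cc(Cc2ccn(Cc3cccc(O[C@H]4CCNC4)c3)n2)c2nn[nH]c2n1` differs from compound 1 in one place: pyrrolidin-3-yl in place of phenyl on an oxygen on an aromatic ring. Among the compounds with values here, no measured pair shows this change, so its effect in this assay is open. The step from compound 1 is expected to be small, a 1.3-fold lower number from compound 1 to compound 4 (0.10 log units; within the scatter), at most a modest lowering. Compound 4 is estimated at 35 nM, in the range 12 nM to 100 nM.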

Compound 4, half-maximal inhibitory concentration: 46 nM
Estimate against measurement, compound 4: 1.3-fold (0.12 log units) below, and the stated range covers the measured number.
By their numbers in this assay, from the lowest: compound 2; then compounds 1, 4 and 3 (each within the scatter of the next).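

In this assay the exchange gives a 1.0-fold higher number from compound 1 to compound 4 (0.02 log units; within the scatter), so at this position, on an oxygen on an aromatic ring, no difference can be read between phenyl and pyrrolidin-3-yl. The aromatic carbon ring can thus give way to a non-aromatic ring with a hydrogen-bond donor and a defined stereocentre, with the number staying within the scatter. Nothing measured here offers an explanation for this result.

As far as these compounds go, whether the opposite stereoisomer of the pyrrolidin-3-yl group would match this remains open. So does the outcome for a piperidine or an open-chain aminoethyl group on the same oxygen.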